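A few compounds are considered here, and "the series" means these few. Any claim that something is new, unique, unknown or untested is made for them only; others in the source may bear on it.

Measured compounds:
- compound 1, `COC(C)CO[C@H](CC=C(C)C)C1=CC(=O)c2c(O)ccc(O)c2C1=O`: 53400 nM
- compound 2, `CC(=O)OCCO[C@H](CC=C(C)C)C1=CC(=O)c2c(O)ccc(O)c2C1=O`: 41500 nM
- compound 3, `COCCO[C@H](CC=C(C)C)C1=CC(=O)c2c(O)ccc(O)c2C1=O`: 62400 nM

All three were tested in a functional assay on HeLa cells (Homo sapiens) for cytotoxicity, read by MTT assay; on this read-out lower numbers stand for stronger inhibition and higher numbers for weaker inhibition. Compound 3 gives the highest of the three numbers, but it does not stand apart: the step of a 1.2-fold higher number from compound 1 to compound 3 (0.07 log units; within the scatter) and the step of a 1.5-fold higher number from compound 2 to compound 3 (0.18 log units; within the scatter) both stay inside the scatter, as does a 1.3-fold lower number from compound 1 to compound 2 (0.11 log units; within the scatter). The three compounds share one core and differ only in the group carried on an oxygen on a saturated carbon.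

Compound 4, `CC(C)=CC[C@@H](OC(=O)CC(C)(O)C(C)C)C1=CC(=O)c2c(O)ccc(O)c2C1=O`, changes that same group again: (2-hydroxy-2,3-dimethylbutyl)carbonyl in place of 2-methoxyethyl on an oxygen on a saturated carbon. For the measured compounds named here, the three measured steps are the only guide, and all of them are small, so no change in the group at this position has so far moved the number in this assay beyond the scatter. The entering group is larger than anything tried, so the uncertainty is wider, but the expected step of a 1.2-fold lower number from compound 3 to compound 4 (0.10 log units; within the scatter) is one of no clear direction. Compound 4 is therefore estimated at 50000 nM, with a likely range from 18000 nM to 140000 nM.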

Compound 4, half-maximal inhibitory concentration: 27700 nM
Compound 4: the middle estimate sits 1.8-fold (0.26 log units) above what was measured, and the stated range covers the measured number.
By their numbers in this assay, from the lowest: compounds 4, 2, 1 and 3 (each within the scatter of the next, the first and the last beyond it).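

In this assay, the step of a 2.3-fold lower number from compound 3 to compound 4 (0.35 log units; beyond the scatter) is the only one among these compounds that goes beyond the scatter, so the group on an oxygen on a saturated carbon can shift the number modestly when (2-hydroxy-2,3-dimethylbutyl)carbonyl replaces 2-methoxyethyl. The new group is not clearly set apart from the other two, though, since a 1.5-fold lower number from compound 2 to compound 4 (0.18 log units; within the scatter) and a 1.9-fold lower number from compound 1 to compound 4 (0.29 log units; within the scatter) both stay within the scatter. No information is available on what lies behind the step.

Still open, from the compounds shown here alone, is whether the carbonyl on this oxygen or the rest of the (2-hydroxy-2,3-dimethylbutyl)carbonyl chain goes with the step, which a plain acetyl on the same oxygen would help to separate. The compounds shown also leave open how an amine or a carboxylic acid in this place would read in this assay.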